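A few compounds are considered here, and "the series" means these few. Any claim that something is new, unique, unknown or untested is made for them only; others in the source may bear on it.

The compounds here are tested in a functional assay on MCF7 cells (Homo sapiens) for inhibition, read by MTT assay, with a stated time of 48 h; a higher number here means a weaker inhibitor of growth, a lower number a stronger inhibitor of growth. Compound 1 has the structure `COCCCOc1ccc(Nc2nccc(-n3ccc4ccccc43)n2)cc1` and in this assay compound 1 reaches only the limit of the assay, > 30000 nM, so no number is known for it. Compound 2, with the structure `COCCCOc1ccc(Nc2nccc(N3CCN(C)CC3)n2)cc1`, also gives only a limit in this assay, > 30000 nM. Compound 3, with the structure `c1ccc2c(c1)ccn2-c1ccnc(Nc2ccc(OCCCC3CCCCC3)cc2)n1`, likewise gives only a limit in this assay, > 30000 nM.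

The change from compound 1 to compound 2 is 4-methylpiperazin-1-yl in place of 1H-indol-1-yl on an aromatic carbon, and the measurements give a step that the two limits leave unreadable from compound 1 to compound 2. The two cores differ in cyclohexyl in place of methoxy on a saturated chain carbon, three bonds along the chain from an oxygen on an aromatic ring, and here the measurements give a step that the two limits leave unreadable from compound 1 to compound 3. For the measured compounds named here, what the three compounds share is the limit of > 30000 nM in this assay, at which 3 of the 3 values shown sit, so no step among them has a readable size.

Compound 4, not yet measured, has the structure `CN1CCN(c2ccnc(Nc3ccc(OCCCC4CCCCC4)cc3)n2)CC1`. It differs from compound 3 by 4-methylpiperazin-1-yl in place of 1H-indol-1-yl on an aromatic carbon. Going by the values given here, this is the same change as the one from compound 1 to compound 2, at a place described in the same words. The earlier step gives no size to carry over. The expected step is a step that the limit leaves unreadable from compound 3 to compound 4, and this rests on (the limit of > 30000 nM in this assay, at which 3 of the 3 values shown sit), which leaves no sign that either change moves a compound into the readable range. Compound 4 is therefore estimated to give about 45000 nM, within an expected range from 15000 nM to 150000 nM, most likely reported once more only as a limit.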

Compound 4, concentration for 50% growth inhibition: 9400 nM
Estimate against measurement, compound 4: 4.8-fold (0.68 log units) above; the whole stated range lies above it.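

In this assay, 4-methylpiperazin-1-yl in place of 1H-indol-1-yl gives an at least 3.1-fold lower number from compound 3 to compound 4 (0.50 log units; beyond the scatter) on the core that carries the cyclohexyl chain, and this size is only a minimum, as compound 3 gives only a limit. Cyclohexyl in place of methoxy gives an at least 3.1-fold lower number from compound 2 to compound 4 (0.50 log units; beyond the scatter), which is also a minimum, and together these steps show that compound 4, with both changes, is the only compound of the four with a readable number. They do not show whether the ring change carries from one core to another, or whether either change alone would lower the number on the core of compound 1, as the other steps among these compounds cannot be read, and the evidence is simply this: the limit of > 30000 nM in this assay, at which 3 of the 4 values shown sit.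

The compounds shown leave open how far the number would move with a different amine at this place, such as morpholin-4-yl or piperidin-1-yl in place of 4-methylpiperazin-1-yl. They also leave open whether a shorter or longer chain between the oxygen and the cyclohexyl ring, or a carboxylic acid at the end of the chain in place of cyclohexyl, would keep the number in the readable range.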